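Methoxy for trifluoromethyl on the benzamide of compound 1

A few compounds are considered here, and "the series" means these few. Any claim that something is new, unique, unknown or untested is made for them only; others in the source may bear on it.

Measured in a functional assay on NUGC-3 cells (Homo sapiens) for antiproliferative activity, read by sulforhodamine B assay; a higher number here means a weaker inhibitor of growth, a lower number a stronger inhibitor of growth:
- compound 1 `Cc1cc(C)c2sc(NC(=O)c3ccc(C(F)(F)F)cc3)nc2c1`: 1.4 ug/mL
- compound 2 `COc1ccccc1NC(=O)Nc1nc2ccc(F)cc2s1`: > 10 ug/mL (a limit, not a number)
- compound 3 `O=C(Nc1nc2ccc(C(F)(F)F)cc2s1)c1ccc([N+](=O)[O-])cc1`: > 10 ug/mL (a limit, not a number)

Among the measured compounds shown here, compound 1 is the only member of the set with a numerical result in this assay; the other two results sit at the limit of > 10 ug/mL in this assay, at which 2 of the 3 values shown sit. Compound 2 gives only a limit in this assay, so nothing beyond that can be said of it. Compound 3 likewise gives only a limit in this assay. For the measured compounds named here, no two measured compounds differ in a single place, so no measured step is available to set the scale for what follows.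

Compound 4 `COc1ccc(C(=O)Nc2nc3cc(C)cc(C)c3s2)cc1` is the next compound to be tested in this assay. It differs from compound 1 in one place: methoxy in place of trifluoromethyl on an aromatic carbon. With no measured step of this kind in the series, the size of the change is open; the expectation is a modest step toward weaker growth inhibition, of about a 2.5-fold higher number from compound 1 to compound 4 (0.40 log units; beyond the scatter), though a result within the scatter of compound 1 cannot be excluded. Compound 4 is thus estimated at 3.5 ug/mL in this assay, with a range of 1.2 ug/mL to 10 ug/mL.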

Compound 4, concentration for 50% growth inhibition: > 10 ug/mL
Compound 4 was reported as a limit (the forecaster's own chance of this, stated with the estimate: 30%); middle value at least 2.8-fold (0.45 log units) away from the limit.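

Among the compounds shown here, this is the first single-place step, and it shows that in this assay the group on this aromatic carbon, para to a large group, matters: methoxy in place of trifluoromethyl gives an at least 7.1-fold higher number from compound 1 to compound 4 (0.85 log units; beyond the scatter). The result for compound 4, > 10 ug/mL, is a limit and not a number. For the compounds shown here, the step is therefore bounded on one side only, and compound 1 remains the single member of the set with a numerical result: the limit of > 10 ug/mL in this assay, at which 3 of the 4 values shown sit.

A single pair cannot show whether trifluoromethyl is specifically required at this carbon, or whether a chlorine, a nitrile or an amine in the same place would keep growth inhibition near that of compound 1, 1.4 ug/mL. Going by these compounds alone, also open is how the two methyl groups on the core of compound 1 contribute, as compound 2 and compound 3 each differ from compound 1 in more than one place and give no step to read.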